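The source may hold more compounds than are shown below. What is called first, only, known or untested is meant among the compounds shown, and "the series" means these compounds.

Values measured in a functional assay on MCF7 cells (Homo sapiens) for antiproliferative activity, read by MTT assay, with a stated time of 24 h; on this read-out lower numbers stand for stronger inhibition and higher numbers for weaker inhibition:

- compound 1 `Cc1ccc(-c2nn(-c3ccccc3)cc2-c2nc3ccccc3[nH]2)cc1`: 7260 nM
- compound 2 `Cc1ccc(-c2nn(-c3ccccc3)cc2-c2nc3ccccc3n2S(=O)(=O)c2ccc(F)cc2)cc1`: 5270 nM
- compound 3 `Cc1ccc(-c2nn(-c3ccccc3)cc2-c2nc3ccccc3n2S(=O)(=O)c2ccc(Br)cc2)cc1`: 3160 nM

Compound 3 stands clearly apart from only one of the others, as shown by a 2.3-fold lower number from compound 1 to compound 3 (0.36 log units; beyond the scatter). Its gap to the remaining compound is smaller: a 1.7-fold lower number from compound 2 to compound 3 (0.22 log units; within the scatter).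

Compound 4 `O=S(=O)(c1ccc(Br)cc1)n1c(-c2cn(-c3ccccc3)nc2-c2ccc(F)cc2)nc2ccccc21` keeps the (4-bromophenyl)sulfonyl group of compound 3 and changes one substituent, 4-methylphenyl to 4-fluorophenyl: fluoro in place of methyl on an aromatic carbon.

Going by the values given here, no measured step makes this swap, so the evidence is indirect. Adding a sulfonyl group gave a 1.4-fold lower number from compound 1 to compound 2 (0.14 log units; within the scatter) and a 2.3-fold lower number from compound 1 to compound 3 (0.36 log units; beyond the scatter), but that group stays the same here. The closest parallel is the single-atom change on the sulfonyl group of compound 3, a 1.7-fold lower number from compound 2 to compound 3 (0.22 log units; within the scatter), which occurred at a different place in the molecule and stayed within the scatter.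

A similarly small effect in this assay therefore seems likely, with no clear direction. The expected change is a 1.1-fold higher number from compound 3 to compound 4 (0.04 log units; within the scatter), which would not exceed the scatter.

The estimated value for compound 4 is 3500 nM, with an expected range of 1700 nM to 7200 nM.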

Compound 4, half-maximal inhibitory concentration: 2630 nM
Beside the measured number, compound 4's estimate is 1.3-fold (0.12 log units) above it; the measured number falls inside the stated range.
By their numbers in this assay, from the lowest: compounds 4, 3, 2 and 1 (each within the scatter of the next, the first and the last beyond it).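

Of the steps shown, this is the only one that touches the 4-methylphenyl group rather than the group on the aromatic nitrogen: in this assay, a 1.2-fold lower number from compound 3 to compound 4 (0.08 log units; within the scatter) comes from swapping it for 4-fluorophenyl. With the (4-bromophenyl)sulfonyl group held fixed, fluoro in place of methyl on this ring therefore leaves the number within the usual scatter, so this one exchange shows no strong response at this position. No measurement here explains the result.

The compounds shown leave open how this position would respond to a different kind of group, such as an amine, a methoxy group or a carboxylic acid. They also leave open whether the same exchange would look alike with the (4-fluorophenyl)sulfonyl group, or with the plain hydrogen of compound 1 on the nitrogen.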